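Swapping acetamido for methoxy on a trithiocarbonate chain

A few compounds are considered here, and "the series" means these few. Any claim that something is new, unique, unknown or untested is made for them only; others in the source may bear on it.

Compound 2 `COc1ccc(C(=O)CSC(=S)SCCNC(C)=O)cc1` was tested in a functional assay on HeLa cells (Homo sapiens) for cytotoxicity, read by resazurin assay, with a stated time of 72 h (on this read-out higher numbers stand for weaker inhibition and lower numbers for stronger inhibition), where compound 2 gives 11100 nM. That is the highest of the three numbers available, though compound 3 `CCSC(=S)SCC(=O)c1cccc(NC(=O)c2ccccc2)c1`, which gives 8230 nM in this assay, lies within the scatter of it, so the two cannot be ordered. Compound 1 `CCSC(=S)SCC(=O)c1ccc(-c2ccc(N)cn2)s1`, which gives 452 nM in this assay, stands far from compound 2, well beyond the scatter. Compound 4 `COCCSC(=S)SCC(=O)c1ccc(OC)cc1` has not yet been measured. It differs from compound 2 in one place: methoxy in place of acetamido on a saturated chain carbon, two bonds along the chain from a sulfur. Among the measured compounds shown here, no measured pair shows this change, so its effect has to be guessed. The chain of compound 4 carries no hydrogen-bond donor, and compound 1, the compound with the lowest number here, gives 452 nM with a chain that carries none either. On that thin basis a small step toward a lower number is expected, a 1.9-fold lower number from compound 2 to compound 4 (0.27 log units; within the scatter), though a step of no size beyond the scatter would not surprise. Compound 4 is expected to give about 6000 nM, within a range from 1500 nM to 20000 nM.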

Compound 4, half-maximal inhibitory concentration: 7880 nM
For compound 4 the middle estimate is 1.3-fold (0.12 log units) below the measured one, and the stated range covers the measured number.
By their numbers in this assay, from the lowest: compound 1; then compounds 4, 3 and 2 (each within the scatter of the next).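

In this assay, among the compounds shown here, the exchange of acetamido for methoxy on a saturated chain carbon, two bonds along the chain from a sulfur, gives a 1.4-fold lower number from compound 2 to compound 4 (0.15 log units; within the scatter) and so leaves no step that can be told from the scatter. For the compounds shown here, at this position on the shared core, the amide hydrogen and the carbonyl of the acetamido group can therefore go without a measurable shift in the number, which the earlier compounds could not show, since none of them formed a pair differing in one place. Nothing at hand gives a reason for this outcome.

As far as these compounds go, whether a free amine, a carboxylic acid or a longer chain at this position would move the number beyond the scatter remains open. So does whether the same exchange would behave alike on the core of compound 1, since this single pair speaks only for the core it shares.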